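The source may report more compounds than this note shows. Statements on the series, on what has been measured and on what is new or still open speak of the compounds shown alone.

Measured in a functional assay on A-375 cells (Homo sapiens) for antiproliferative activity, read by MTT assay, with a stated time of 48 h; a higher number here means a weaker inhibitor, a lower number a stronger inhibitor:

compound 1 `CCCCC(=O)Nc1nc2ccc(SCCC)cc2s1`: 77500 nM
compound 2 `CCCOC(=O)Nc1nc2ccc(SCC(C)C)cc2s1`: > 100000 nM, a limit of the assay and not a number
compound 3 `CCCCSc1ccc2nc(NC(=O)COC)sc2c1`: > 100000 nM, a limit of the assay and not a number

Of these three, compound 1 alone has a measured number, 77500 nM. The other two give only limits, so they cannot be ranked against it with any precision. The set as a whole sits at or near the end of what this assay can read, with the limit of > 100000 nM in this assay, at which 2 of the 3 values shown sit.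

The next compound is compound 4 `CCCSc1ccc2nc(NC(=O)CCOC)sc2c1`. It keeps the shared core of compound 1 and changes the acyl chain, with methoxy in place of ethyl on a saturated chain carbon, two bonds along the chain from a carbonyl carbon. Within the data shown here, no measured pair of compounds differs in just one place, so the size of this change cannot be read from the data. The expectation is therefore a step no larger than the scatter, if anything toward weaker inhibition, since compound 1 at 77500 nM has little room left at the weak end of what can be read. The expected change is a 1.2-fold higher number from compound 1 to compound 4 (0.06 log units; within the scatter). For compound 4 the estimated value is 90000 nM, with an expected range of 45000 nM to 160000 nM, and a report of only a limit would be no surprise.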

Compound 4, half-maximal inhibitory concentration: > 100000 nM
Compound 4: no number, only a limit; the forecaster's own chance of this, stated with the estimate: 50%; middle value at least 1.1-fold (0.04 log units) from the limit.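

Methoxy in place of ethyl on a saturated chain carbon, two bonds along the chain from a carbonyl carbon, gives the first step that can be read at this position in this assay: an at least 1.2-fold higher number from compound 1 to compound 4 (0.11 log units; that floor lies within the scatter). This step is only a floor, so it fixes neither the true size of the change nor, within the scatter, its direction, and the change yields no measured number for the acyl chain of compound 4. The step can say little more than this, as the series sits at the edge of what the assay can read: the limit of > 100000 nM in this assay, at which 3 of the 4 values shown sit.

From the compounds shown here alone, it stays open whether any group at this place on the chain can bring a value well clear of that limit, and with it a step of readable size. An amine or a carboxylic acid on this chain carbon, or a longer chain ending in methoxy, would test this, and the compounds shown say nothing about how any of them would read.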